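From 4-methylbenzyl to 1-phenylethyl on the amide nitrogen

This account rests on a few compounds, and the source may have more. Where it says the series, first, only, none or still open, it means among the compounds named here.

Compound 1 `O=C(NC1CCCCC1)c1nc[nH]c1C(=O)Nc1ccc(Cl)c(Cl)c1`: 33100 nM
Compound 2 `O=C(Nc1ccc(Cl)c(Cl)c1)c1nc[nH]c1C(=O)NCc1ccc(Cl)cc1`: 16200 nM
Compound 3 `Cc1ccc(CNC(=O)c2[nH]cnc2C(=O)Nc2ccc(Cl)c(Cl)c2)cc1`: 21400 nM

These three compounds were measured in a functional assay on HL-60 cells (Homo sapiens), with a stated time of 2 days; on this read-out higher numbers stand for weaker inhibition and lower numbers for stronger inhibition. Compound 3 lies within the scatter of both of the others, so the numbers give it no distinct place among them. Compound 4 `C[C@H](NC(=O)c1[nH]cnc1C(=O)Nc1ccc(Cl)c(Cl)c1)c1ccccc1` has not yet been measured. Its structure departs from that of compound 3 as follows: 1-phenylethyl in place of 4-methylbenzyl on an amide-type nitrogen. Thus 1-phenylethyl stands in place of 4-methylbenzyl on an amide-type nitrogen, and a defined stereocentre enters. Going by the values given here, only one measured step bears on this change, and only loosely: a 1.3-fold higher number from compound 2 to compound 3 (0.12 log units; within the scatter). That step, methyl in place of chloro on an aromatic carbon, stayed within the scatter. Among the compounds with values here, no measured pair tests 1-phenylethyl or a stereocentre, so the expectation is tentative. The expected change is a 1.0-fold higher number from compound 3 to compound 4 (0.01 log units; within the scatter), with no step beyond the scatter anticipated in this assay. The estimate for compound 4 is an expected 22000 nM, within a range from 10000 nM to 46000 nM.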

Compound 4, half-maximal inhibitory concentration: 9200 nM
Beside the measured number, compound 4's estimate is 2.4-fold (0.38 log units) above it; the measured number lies below the stated range.
By their numbers in this assay, from the lowest: compounds 4, 2, 3 and 1 (each within the scatter of the next, the first and the last beyond it).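

In this assay, the change on the amide-type nitrogen from 4-methylbenzyl to 1-phenylethyl, which keeps the same atoms joined differently, gave a 2.3-fold lower number from compound 3 to compound 4 (0.37 log units; beyond the scatter) and is the first step shown here to leave the scatter. This position therefore responds to how the eight carbons are arranged, although the size of the response is modest. The comparison with 4-chlorobenzyl gives a 1.8-fold lower number from compound 2 to compound 4 (0.25 log units; within the scatter) and remains within the scatter, so 1-phenylethyl is separated from only one of the two benzyl groups, and no measured evidence accounts for the step.

The compounds shown leave open whether the step follows the change of skeleton or the defined stereocentre. Unsubstituted benzyl and the opposite stereoisomer of 1-phenylethyl would each bear on that question.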